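Replacing (4-methylpiperazin-1-yl)methyl with isopropyl

The source may hold more compounds than are shown below. What is called first, only, known or untested is meant among the compounds shown, and "the series" means these compounds.

Measured in a functional assay on the whole organism with Mus musculus as the target, in the rotarod test; on this read-out lower numbers stand for an effect already at smaller amounts and higher numbers for an effect only at larger amounts of compound:
- compound 1 `NCC(=O)NCC(=O)Nc1ccc([N+](=O)[O-])cc1C(=O)c1ccccc1Cl` gives 63.9 mg/kg as a number
- compound 2 `CN1CCN(CC(=O)NCC(=O)N(C)c2ccc(Cl)cc2C(=O)c2ccccc2Cl)CC1` gives > 100 mg/kg as a limit

Compound 2 stands at > 100 mg/kg, which is a limit and not a number. Compound 3 `CC(C)C(=O)NCC(=O)N(C)c1ccc(Cl)cc1C(=O)c1ccccc1Cl` carries isopropyl in place of (4-methylpiperazin-1-yl)methyl on a carbonyl carbon. For the measured compounds named here, no measured step covers this change, so its size in this assay is uncertain. A shift toward lower numbers is expected, resting only on compound 1 giving 63.9 mg/kg as a number. The expected change is an at least 1.6-fold lower number from compound 2 to compound 3 (0.22 log units; that floor lies within the scatter) as estimated here. For compound 3 the estimated value is 60 mg/kg, with an expected range from 20 mg/kg to 180 mg/kg.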

Compound 3, dose for half-maximal effect: > 100 mg/kg
Compound 3: a limit, no number; the forecaster's own chance of this, stated with the estimate: 40%; middle value at least 1.6-fold (0.22 log units) away from the limit.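

In this assay, compound 2 and compound 3 both give only a limit and no number, so no step can be read between them: the limit of > 100 mg/kg in this assay, at which 2 of the 3 values shown sit.

From the compounds shown here alone, whether isopropyl in place of (4-methylpiperazin-1-yl)methyl on a carbonyl carbon changes the read-out at all stays open.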